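A few compounds are considered here, and "the series" means these few. Any claim that something is new, unique, unknown or untested is made for them only; others in the source may bear on it.

Measured so far in an ADME assay on MT4 cells (Homo sapiens) for cytotoxicity, read by MTT assay, with a stated time of 96 h; on this read-out lower numbers stand for higher toxicity in this test and higher numbers for lower toxicity in this test: compound 1 `COc1ccc(-c2nc3cc(Cl)c(Cl)cc3[nH]2)cc1` gives 1000 nM. Compound 2 `CN1CCN(CC(=O)Nc2ccc(-c3nc4cc(C(F)(F)F)ccc4n3C)cc2)CC1` gives 22000 nM. Compound 3 `O=C(O)CCC(=O)Nc1ccc(-c2nc3cc(C(F)(F)F)ccc3[nH]2)cc1` gives > 100000 nM, which is a limit of the assay and not a number; (the limit of > 100000 nM in this assay, at which 1 of the 3 values shown sits).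

Of the three values, compound 3 alone sits at the limit, while compound 1 and compound 2 return numbers.

Compound 4 `CCN(CC)CC(=O)Nc1ccc(-c2nc3cc(C(F)(F)F)ccc3[nH]2)cc1` is not yet measured. It differs from compound 3 in one place: diethylamino in place of carboxymethyl on a saturated chain carbon bound to a carbonyl carbon.

For the measured compounds named here, no measured step covers this change. The other compound whose amide chain ends in a nitrogen is compound 2, and in this assay compound 2 gives 22000 nM. On that basis the step is expected to run downward, beyond the scatter, by an at least 3.3-fold lower number from compound 3 to compound 4 (0.52 log units; beyond the scatter). Compound 4 is estimated at 30000 nM, with a range from 10000 nM to 100000 nM.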

Compound 4, half-maximal cytotoxic concentration: 8000 nM
The estimate for compound 4 lay 3.8-fold (0.57 log units) above the measured number; measured number below the stated range.
By their numbers in this assay, from the lowest: compound 1; then compound 4; then compound 2. At a limit, above all of these: compound 3.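

In this assay, diethylamino in place of carboxymethyl on a saturated chain carbon bound to a carbonyl carbon gives an at least 12-fold lower number from compound 3 to compound 4 (1.09 log units; beyond the scatter), so this position can move the read-out by a large margin. Compound 3 stands at a limit and not a number: the limit of > 100000 nM in this assay, at which 1 of the 4 values shown sits.
The step therefore gives only a bound on the change, while compound 4 gives a number at this position.

From the compounds shown here alone, whether the step follows from losing the carboxylic acid or from gaining the amine stays open. A methyl ester or a plain alkyl chain at this place would separate the two.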